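Chloro on the aryl ring, carried to a second core

This account rests on a few compounds, and the source may have more. Where it says the series, first, only, none or still open, it means among the compounds named here.

Compound 1 `COc1ccc(-c2nc(SCC(=O)c3sc(-c4ccccc4)nc3C)nc(N)c2C#N)cc1` and compound 2 `COc1ccc(-c2nc(SCC(=O)c3sc(-c4ccc(Cl)cc4)nc3C)nc(N)c2C#N)cc1` share one core; compound 3 `COc1ccc(-c2nc(C)c(C(=O)CSc3nc(-c4ccccc4)c(C#N)c(=O)[nH]3)s2)cc1` and compound 4 `COc1ccc(-c2nc(C)c(C(=O)CSc3nc(-c4cccc(Cl)c4)c(C#N)c(=O)[nH]3)s2)cc1` share another. The difference between the two cores is not broken down here. In a functional assay on U-87MG ATCC cells for antiproliferative activity against U-87 MG (Homo sapiens), read by MTT assay, with a stated time of 48 h, tested at 100 uM (a lower number here means a stronger effect, a higher number a weaker effect of the compound at the concentration tested), compound 1 gives 17.2%. In this assay compound 2 gives 0.79%. The change between them is chloro in place of hydrogen on an aromatic carbon, and it made the step of a number 16.4 percentage points lower from compound 1 to compound 2 (beyond the scatter). In this assay compound 3 gives 10.9%, a read-out within the scatter of compound 1 and beyond the scatter from compound 2.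

Compound 4 carries the change (chloro in place of hydrogen on an aromatic carbon). This is the same kind of change as that seen on the first core, with the chloro entering para to a large group there and meta to a large group here, so it is not the same change. The expectation for compound 4 rests on that single earlier example. For compound 4 a step of a number 6.9 percentage points lower from compound 3 to compound 4 (within the scatter) is expected because a number 16.4 percentage points lower from compound 1 to compound 2 (beyond the scatter) moved the read-out in the same direction on the other core. The read-out cannot fall far below zero, so the expected step is shortened. Compound 4 is estimated at 4%, expected to lie between 0% and 12%.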

Compound 4, a percentage reported as activity, at one concentration (the size of the read-out at that concentration, not a potency): 40.6%
Compound 4: middle estimate off by 36.6 percentage points, on the low side; measured number above the stated range.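

In this assay, the change from phenyl to 3-chlorophenyl gives a number 29.7 percentage points higher from compound 3 to compound 4 (beyond the scatter), so compound 4 reads weaker than compound 3 and the chloro change does not keep its direction from one core to the other: the same change on two cores in this assay, a number 16.4 percentage points lower (beyond the scatter) from compound 1 to compound 2 and a number 29.7 percentage points higher (beyond the scatter) from compound 3 to compound 4, 46.1 percentage points apart, beyond the scatter of two such steps This does not show that the core alone sets the direction, as the chloro in compound 4 sits meta to a large group while the chloro in compound 2 occupies a different place, so core and placement vary together in these two pairs. Among these compounds, with only one pair per core, and a read-out at a single concentration rather than a potency, the data also support no general rule that chloro helps on the core of compound 1 or harms on the core of compound 3.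

On these data alone, it remains open how 3-chlorophenyl would read on the core of compound 1, and how a chloro placed as in compound 2 would read on the core of compound 3, which are the two comparisons that could separate the effect of the core from that of placement. As far as these compounds go, it is also open whether a different group at the place taken by chloro in compound 4, such as fluoro, methoxy or an amine, would follow compound 4 or compound 3.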